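A few compounds are considered here, and "the series" means these few. Any claim that something is new, unique, unknown or untested is made for them only; others in the source may bear on it.

Three measured compounds frame this account. Compound 1 `COc1cc(C(=O)/C=C\Nc2ccc(-c3nc4cc(OC)c(OC)c(OC)c4s3)cc2)c(Br)c(OC)c1OC` gives 13600 nM in a functional assay on A549 cells (Homo sapiens) for antiproliferative activity, read by sulforhodamine B assay, with a stated time of 48 h; a lower number here means a stronger inhibitor, a higher number a weaker inhibitor. Compound 2 `COc1ccc2nc(-c3ccc(N/C=C\C(=O)c4ccc(OC)c(O)c4)c(C)c3)sc2c1` gives 18000 nM in this assay, and compound 3 `COc1cc(OC)c2sc(-c3ccc(N/C=C\C(=O)c4ccc(OC)c([N+](=O)[O-])c4)c(C)c3)nc2c1` gives 12100 nM in this assay. Within the data shown here, of these three numbers, the one for compound 2 is the highest, yet its gap to compound 1 and its gap to compound 3 both lie within the usual scatter, so no order among the three can be read from them.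

The step under consideration leads from compound 2 to compound 4 `COc1ccc2nc(-c3ccc(N/C=C\C(=O)c4ccc(OC)c([N+](=O)[O-])c4)c(C)c3)sc2c1`, which has not yet been measured. The change is nitro in place of hydroxy on an aromatic carbon, placed on an aromatic carbon of a six-membered aromatic ring of carbon only; read one bond further out, a 3-hydroxy-4-methoxyphenyl becomes a 4-methoxy-3-nitrophenyl. Among the measured compounds shown here, no measured pair shows exactly this exchange on a shared core, so the expectation rests on compound 3, which carries the same nitro group on a related core and gives 12100 nM. On that basis the step is expected to be small, and the author expects a 1.4-fold lower number from compound 2 to compound 4 (0.14 log units; within the scatter), no step beyond the scatter, in this assay. Compound 4 is therefore estimated at 13000 nM, within a range from 6000 nM to 30000 nM.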

Compound 4, half-maximal inhibitory concentration: 13600 nM
Compound 4: middle estimate off by 1.0-fold (0.02 log units), on the low side; the range from low to high includes it.
By their numbers in this assay, from the lowest: compounds 3, 1, 4 and 2 (each within the scatter of the next).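

In this assay, nitro in place of hydroxy on this aromatic carbon, ortho to a methoxy group, gives a 1.3-fold lower number from compound 2 to compound 4 (0.12 log units; within the scatter), and this is the first pair shown that isolates the exchange on a shared core. On this core, then, the 3-hydroxy-4-methoxyphenyl and the 4-methoxy-3-nitrophenyl cannot be told apart in this read-out, even though the exchange gives up the hydrogen-bond donor of the hydroxy and brings in a group with more heavy atoms and a double bond outside the aromatic rings. No measurement at hand offers an explanation for why the two groups read alike at this position.

Whether an amine, a carboxylic acid or a plain hydrogen on this same aromatic carbon would give a step beyond the scatter remains open, so the compounds shown do not establish how far this position tolerates change. The compounds shown also hold this exchange on one core only, which leaves open whether hydroxy and nitro would read alike on the core of compound 3 as well.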